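The source may report more compounds than this note shows. Statements on the series, on what has been measured and on what is new or still open speak of the compounds shown alone.

Compound 1 `COc1ccccc1N1CCN(C(=O)CN2C(=O)CC(C)(c3ccccc3)C2=O)CC1`: 100 mg/kg in a functional assay on the whole organism (strain CD-1) with Mus musculus as the target, with a stated time of 0.5 h; a lower number here means that less compound is needed, a higher number that more compound is needed for the effect
Compound 2 `CC1(c2ccccc2)CC(=O)N(CC(=O)N2CCN(c3ccc(F)cc3)CC2)C1=O`: 300 mg/kg

Compound 2 stands highest of the two numbers in this assay; the step of a 3.0-fold higher number from compound 1 to compound 2 (0.48 log units; beyond the scatter) is the only measured one. Compound 3 `CC1(c2ccccc2)CC(=O)N(CC(=O)N2CCN(c3cccc(C(F)(F)F)c3)CC2)C1=O` differs from compound 2 by 3-(trifluoromethyl)phenyl in place of 4-fluorophenyl on an amine nitrogen in a ring. Within the data shown here, the single step bears on the same ring position but gives no direction for this new group, so no step beyond the scatter is expected: no change at the digits printed from compound 2 to compound 3 (within the scatter). Compound 3 is therefore estimated at 300 mg/kg, within 100 mg/kg to 1000 mg/kg.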

Compound 3, minimum effective dose: 300 mg/kg
For compound 3 middle estimate and measured number coincide at the digits printed, within the range that was stated.
By their numbers in this assay, from the lowest: compound 1; then compounds 2 and 3 (each within the scatter of the next).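

In this assay, 3-(trifluoromethyl)phenyl in place of 4-fluorophenyl on the ring amine nitrogen gives no change at the digits printed from compound 2 to compound 3 (within the scatter) for this change, so these two aryl groups read alike here. The same group in place of 2-methoxyphenyl gives a 3.0-fold higher number from compound 1 to compound 3 (0.48 log units; beyond the scatter) as a second step of the same size, and compound 1 keeps the lowest number of the three. No supporting data bear on the reason for this.
Open, as far as these compounds go, is how an unsubstituted phenyl or a pyridine ring would read on this nitrogen, and whether a 2-ethoxyphenyl group would match 2-methoxyphenyl.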